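Chloro for Methoxy on a Shared Core

This account rests on a few compounds, and the source may have more. Where it says the series, first, only, none or still open, it means among the compounds named here.

Compound 2 `COc1ccc(C2=NN(C3=NC(=O)/C(=C4\C(=O)Nc5ccc(Cl)cc54)S3)C(c3ccc(OC)cc3)C2)cc1` stands level with compound 1 `COc1ccc(C2=NN(C3=NC(=O)/C(=C4\C(=O)Nc5ccc(Br)cc54)S3)C(c3ccc(OC)cc3)C2)cc1`: in a functional assay on cells (Cancer cell lines, Homo sapiens) for cytotoxicity, read by sulforhodamine B assay, with a stated time of 48 h (on this read-out lower numbers stand for stronger inhibition of growth and higher numbers for weaker inhibition of growth), compound 1 gives 710 nM and compound 2 gives 710 nM, and no change at the digits printed from compound 1 to compound 2 (within the scatter). Compound 3 `COc1ccc(C2=NN(C3=NC(=O)/C(=C4\C(=O)Nc5ccc(Cl)cc54)S3)C(c3ccc(Cl)cc3)C2)cc1` differs from compound 2 by chloro in place of methoxy on an aromatic carbon, that is 4-methoxyphenyl to 4-chlorophenyl. Going by the values given here, no measured step covers this kind of change; the only step known, a halogen swap, was flat. The account therefore expects no step beyond the scatter in this assay, namely no change at the digits printed from compound 2 to compound 3 (within the scatter). Compound 3 is estimated at 710 nM, with a range from 250 nM to 2000 nM.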

Compound 3, concentration for total growth inhibition: 740 nM
Beside the measured number, compound 3's estimate is 1.0-fold (0.02 log units) below it; the range from low to high includes it.
By their numbers in this assay, from the lowest: compounds 1, 2 and 3 (each within the scatter of the next).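

In this assay, 4-chlorophenyl in place of 4-methoxyphenyl gives a 1.0-fold higher number from compound 2 to compound 3 (0.02 log units; within the scatter) on the shared core. The earlier pair varied only one halogen for another, whereas this step shows that a methoxy on this ring can give way to a chloro with the read-out staying within the scatter. Nothing on hand bears on the reason for this result.

On these data alone, whether an amine, a carboxylic acid or a longer alkoxy chain at this position would also stay level with compound 2 remains open. So does the effect of any such exchange on the remaining 4-methoxyphenyl group.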